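This account rests on a few compounds, and the source may have more. Where it says the series, first, only, none or still open, it means among the compounds named here.

Measured compounds:
compound 1, `NC(=S)N/N=C/c1ccc2ccccc2n1`, 100000 nM
compound 2, `CN(C)C(=S)N/N=C/c1cnc2ccccc2n1`, 450 nM

Both were tested in a functional assay on HT-29 cells (Homo sapiens) for antiproliferative activity, read by sulforhodamine B assay, with a stated time of 72 h; a lower number here means a stronger inhibitor, a higher number a weaker inhibitor. Compound 1 gives 100000 nM, the highest of the two numbers, while compound 2 gives 450 nM, a far lower number, well beyond the scatter. For the measured compounds named here, the two compounds differ in more than one place, so no single step between them is counted; their values show only that compound 1 is the weaker of the pair. The unmeasured compound 3, `Fc1ccccc1NC(=S)N/N=C/c1ccc2ccccc2n1`, differs from compound 1 by 2-fluorophenyl in place of hydrogen on an amide-type nitrogen. Going by the values given here, no measured pair isolates this change. Because compound 1 gives 100000 nM, the weakest result seen, a clearly lower number for compound 3 is expected, an estimated step of a 20-fold lower number from compound 1 to compound 3 (1.30 log units; beyond the scatter), though with wide uncertainty. Compound 3 is therefore estimated at 5000 nM, within a range of 500 nM to 50000 nM.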

Compound 3, half-maximal inhibitory concentration: > 100000 nM
Compound 3: no number, only a limit; the forecaster's own chance of this, stated with the estimate: 25%; middle value at least 20-fold (1.30 log units) away from the limit.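

In this assay, compound 3 gives only a limit, not a number: > 100000 nM. Putting 2-fluorophenyl in place of hydrogen on the amide-type nitrogen therefore brings no measurable gain, with a number no lower from compound 1 to compound 3 (the limit leaves the size open), so this added ring alone does not lift the core of compound 1 into a range where a number can be read. The size of this step cannot be read, because the comparison runs into a limit: the limit of > 100000 nM in this assay, at which 1 of the 3 values shown sits.

Going by these compounds, whether a different group on this nitrogen, such as a short chain ending in an amine or a benzyl group, would give a lower number remains open. On these data alone, compound 2 differs from compound 1 in more than one place, so which of its differences goes with its much lower number also remains open.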